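Bromo to 4-fluorophenyl on the aniline ring of compound 1

A few compounds are considered here, and "the series" means these few. Any claim that something is new, unique, unknown or untested is made for them only; others in the source may bear on it.

Measured so far:
compound 1, `CCc1cc(Br)cc(Nc2cc(C)nc(N)n2)c1` — an assay on cells for inhibition of S-adenosylmethionine decarboxylase proenzyme (Homo sapiens), read by mass spectrometry, at pH 7.2; on this read-out higher numbers stand for weaker inhibition and lower numbers for stronger inhibition > 180000 nM
compound 2, `Cc1cc(Nc2cc(Br)cc(OCC(F)(F)F)c2)nc(N)n1` — this assay 44000 nM

Compound 1 sits at a limit in this assay: its value of > 180000 nM is a limit, not a number, as recorded in the limit of > 180000 nM in this assay, at which 1 of the 2 values shown sits. Compound 2 gives a real number, 44000 nM. Going by the values given here, the one step with a number, an at least 4.0-fold lower number from compound 1 to compound 2 (0.61 log units; beyond the scatter), concerns the 2,2,2-trifluoroethoxy in place of ethyl and says nothing about the bromo position.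

Compound 3, `CCc1cc(Nc2cc(C)nc(N)n2)cc(-c2ccc(F)cc2)c1`, differs from compound 1 by 4-fluorophenyl in place of bromo on an aromatic carbon. Among the compounds with values here, no measured step touches that position, so there is no anchor for the size or direction of the change. Within the data shown here, the only guide is the shared core and the fact that compound 1 is itself unquantified. Compound 3 is therefore expected near the weak end, with wide uncertainty, estimated at 90000 nM (range 15000 nM to 400000 nM), an expected step of an at least 2.0-fold lower number from compound 1 to compound 3 (0.30 log units; that floor lies within the scatter).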

Compound 3, half-maximal inhibitory concentration: > 180000 nM
Compound 3: no number, only a limit (the forecaster's own chance of this, stated with the estimate: 40%); middle value at least 2.0-fold (0.30 log units) from the limit.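

Compound 1 and compound 3 both rest at a limit, not a number, so the step between them cannot be read: the limit of > 180000 nM in this assay, at which 2 of the 3 values shown sit. The compounds shown leave open whether 4-fluorophenyl in place of bromo shifts inhibition on the shared core at all, and in which direction.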